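Notes on one chain extension across two related cores

The source may report more compounds than this note shows. Statements on the series, on what has been measured and on what is new or still open speak of the compounds shown alone.

Measured compounds:
compound 1, `CCCCCC[C@@]1(C)SC(O)=CC1=O`: in a functional assay on MCF7 cells (Homo sapiens) for inhibition (on this read-out higher numbers stand for weaker inhibition and lower numbers for stronger inhibition), compound 1 gives 16.5 ug/mL
compound 2, `CCCCCCCC[C@@]1(C)SC(O)=CC1=O`: in this assay compound 2 gives 12.6 ug/mL
compound 3, `C=CCOC1=CC(=O)S[C@]1(C)CCCCCC`: in this assay compound 3 gives only a limit, > 50 ug/mL

The change from compound 1 to compound 2 is ethyl in place of hydrogen on a saturated chain carbon, six bonds along the chain from a saturated ring carbon. Its step is a 1.3-fold lower number from compound 1 to compound 2 (0.12 log units; within the scatter), so the two values are not distinguished. Compound 3 stands at the limit of > 50 ug/mL in this assay, at which 1 of the 3 values shown sits, a limit of the assay and not a number. How the core of compound 3 differs from the core of compound 1 is not broken down here.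

Compound 4, `C=CCOC1=CC(=O)S[C@]1(C)CCCCCCCC`, is not yet measured. It differs from compound 3 by ethyl in place of hydrogen on a saturated chain carbon, six bonds along the chain from a saturated ring carbon, the same change at the same place as that from compound 1 to compound 2. On the evidence of a 1.3-fold lower number from compound 1 to compound 2 (0.12 log units; within the scatter) the change is expected to move the value little, giving an expected step that the limit leaves unreadable from compound 3 to compound 4. Because compound 3 sits at the limit of > 50 ug/mL in this assay, at which 1 of the 3 values shown sits, compound 4 is most likely to return a limit as well; as a number, compound 4 is estimated at 60 ug/mL, with a range from 30 ug/mL to 150 ug/mL.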

Compound 4, half-maximal inhibitory concentration: > 50 ug/mL
Compound 4: only a limit was reported (the forecaster's own chance of this, stated with the estimate: 70%); the middle value is on the limit's open side.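

In this assay compound 4 gives > 50 ug/mL, a limit of the assay and not a number. Compound 3 also gives only a limit, so no step can be read between compound 3 and compound 4: the limit of > 50 ug/mL in this assay, at which 2 of the 4 values shown sit.

The compounds shown leave open whether ethyl in place of hydrogen changes the value at all on the core of compound 3.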